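Phenoxy for Bromo Across Two Triazole Nucleoside Cores

A few compounds are considered here, and "the series" means these few. Any claim that something is new, unique, unknown or untested is made for them only; others in the source may bear on it.

Measured compounds:
Compound 1, `O=c1[nH]c(=O)n([C@H]2C[C@H](O)[C@@H](CO)O2)cc1-c1cn(-c2ccc(Br)cc2)nn1`: 1370 nM
Compound 2, `O=c1[nH]c(=O)n([C@H]2C[C@H](O)[C@@H](CO)O2)cc1-c1cn(-c2ccc(Oc3ccccc3)cc2)nn1`: 280 nM
Compound 3, `O=c1[nH]c(=O)n([C@H]2C[C@H](O)[C@@H](CO)O2)cc1-c1cnnn1-c1ccc(Br)cc1`: 8000 nM

Of the compounds shown here, three have been measured in an ADME assay on HeLa cells (Homo sapiens) for cytotoxicity, read by cell counting, with a stated time of 4 days; on this read-out lower numbers stand for stronger inhibition and higher numbers for weaker inhibition. Compound 1 and compound 3 are built from the same atoms joined differently; the difference between the two cores is not broken down here. In this assay compound 3 gives 8000 nM, the highest of the three numbers, while compound 1 gives 1370 nM and compound 2 gives 280 nM.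

Within the core of compound 1, one change has been measured: phenoxy in place of bromo on an aromatic carbon. It produced a 4.9-fold lower number from compound 1 to compound 2 (0.69 log units; beyond the scatter).

Compound 4, `O=c1[nH]c(=O)n([C@H]2C[C@H](O)[C@@H](CO)O2)cc1-c1cnnn1-c1ccc(Oc2ccccc2)cc1`, has not yet been measured. It stands to compound 3 as compound 2 stands to compound 1: phenoxy in place of bromo on an aromatic carbon. The place of the change is the same in both pairs, so this is the same change made on the core of compound 3.

Among the compounds with values here, with only one earlier instance of this change, the expectation for compound 4 rests on compound 1 and compound 2 alone, and on the assumption that the change carries over to the other core; nothing measured on the core of compound 3 confirms or denies that. Because a 4.9-fold lower number from compound 1 to compound 2 (0.69 log units; beyond the scatter) was a modest but clear step, the expected step for compound 4 is a 4.7-fold lower number from compound 3 to compound 4 (0.67 log units; beyond the scatter). Compound 4 is therefore estimated at 1700 nM in this assay, expected to fall between 600 nM and 4800 nM.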

Compound 4, half-maximal inhibitory concentration: 42000 nM
For compound 4 the middle estimate is 25-fold (1.39 log units) below the measured one, outside the stated range (above it).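

On the core of compound 3, phenoxy in place of bromo gave a 5.3-fold higher number from compound 3 to compound 4 (0.72 log units; beyond the scatter) in this assay, the opposite direction to the step seen on the core of compound 1. Set side by side, the two steps show that this change did not carry from one core to the other in this series, and the gap between them is larger than repeated measurements would explain: the same change on two cores in this assay, a 4.9-fold lower number (0.69 log units; beyond the scatter) from compound 1 to compound 2 and a 5.3-fold higher number (0.72 log units; beyond the scatter) from compound 3 to compound 4, 26-fold (1.41 log units) apart, beyond the scatter of two such steps. Within the data shown here, this shows that, for these two pairs, the result of the change depended on the core that carried it, but it does not show what in the two cores produces the reversal, and with only one change tested on both, it does not show whether any other change would also reverse.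

As far as these compounds go, it remains open whether a different group in place of bromo, such as an amine, a carboxylic acid or a longer chain on the same aromatic carbon, would also move in opposite directions on the two cores. From the compounds shown here alone, it is equally open whether the split seen here with phenoxy would appear outside this assay in any other read-out.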